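Methyl groups on the amide of a naphthyl-pyridine acrylamide

A few compounds are considered here, and "the series" means these few. Any claim that something is new, unique, unknown or untested is made for them only; others in the source may bear on it.

The measured compounds and their values:
- compound 1 `CNC(=O)/C=C/c1ccncc1-c1ccc2ccccc2c1`, an assay on a protein complex for inhibition of CDK8/Cyclin C (Homo sapiens), with a stated time of 1 h (on this read-out higher numbers stand for weaker inhibition and lower numbers for stronger inhibition), 12.4 nM
- compound 2 `CNC(=O)CCc1ccncc1-c1ccc2ccccc2c1`, this assay 21.1 nM
- compound 3 `O=C(O)CCNC(=O)/C=C/c1ccncc1-c1ccc2ccccc2c1`, this assay 870 nM

Compound 3 gives the highest number of the three, well beyond the scatter from both others: the step of a 70-fold higher number from compound 1 to compound 3 (1.85 log units; beyond the scatter) is the largest movement seen here. Compound 4 `CN(C)C(=O)/C=C/c1ccncc1-c1ccc2ccccc2c1` differs from compound 3 by dimethylamino in place of (2-carboxyethyl)amino on a carbonyl carbon. Going by the values given here, the step that bears on this change is the one from compound 1 to compound 3, which added the (2-carboxyethyl) chain and cost much; compound 4 takes that chain away again, although it also leaves the amide without a hydrogen, a change for which no measured pair exists. Compound 2 shows only that the chain between the amide and the ring can be altered within the scatter. A large fall in number is therefore expected in this assay, of about a 29-fold lower number from compound 3 to compound 4 (1.46 log units; beyond the scatter), though with less certainty than if the hydrogen had been kept. For compound 4 the estimate is 30 nM, within 8 nM to 120 nM.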

Compound 4, half-maximal inhibitory concentration: 30.1 nM
The estimate for compound 4 lay 1.0-fold (0.00 log units) below the measured number; the range from low to high includes it.
By their numbers in this assay, from the lowest: compounds 1, 2 and 4 (each within the scatter of the next, the first and the last beyond it); then compound 3.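

In this assay, dimethylamino in place of (2-carboxyethyl)amino on the carbonyl carbon gives a 29-fold lower number from compound 3 to compound 4 (1.46 log units; beyond the scatter) and so recovers most of the ground lost in compound 3, even though the amide hydrogen is gone as well. That hydrogen now has a measured step of its own: methyl in its place gives a 2.4-fold higher number from compound 1 to compound 4 (0.39 log units; beyond the scatter) and this modest change, though beyond the scatter, is much smaller than the step from the chain. The unsaturated dimethyl amide also cannot be separated from the saturated methyl amide, with a 1.4-fold higher number from compound 2 to compound 4 (0.15 log units; within the scatter) lying within the scatter, and nothing available explains any of these steps.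

The compounds shown leave open whether a propyl or 2-aminoethyl group on the amide nitrogen would cost as much as the 2-carboxyethyl chain of compound 3. They also leave open how a saturated dimethyl amide would read.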